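Thienopyrimidinone Ureas at the Melanin-Concentrating Hormone Receptor

The source may hold more compounds than are shown below. What is called first, only, known or untested is meant among the compounds shown, and "the series" means these compounds.

Compound 1 `Cc1ccc(-c2cc3ncn([C@H]4CCN(C(=O)N(C)[C@H]5CCN(C)C5)C4)c(=O)c3s2)cc1`: 15 nM
Compound 2 `Cc1ccc(-c2cc3ncn([C@H]4CCN(C(=O)N(C)[C@H]5CCN(C)C5)C4)c(=O)c3s2)c(C)c1`: 49 nM
Compound 3 `COc1ccc(-c2cc3ncn([C@H]4CCN(C(=O)N(C)[C@H]5CCN(C)C5)C4)c(=O)c3s2)cc1`: 21 nM

Three analogues sharing one core have been measured in an assay on isolated protein for binding affinity to melanin-concentrating hormone receptor 1 (Homo sapiens); a lower number here means a stronger inhibitor, a higher number a weaker inhibitor. Compound 3 gives 21 nM and stands second highest of the three, close to compound 1 but separated from compound 2 by a gap beyond the scatter. Compound 4 `CCOc1ccc(-c2cc3ncn([C@H]4CCN(C(=O)N(C)[C@H]5CCN(C)C5)C4)c(=O)c3s2)c(Cl)c1` differs from compound 3 in one place: 2-chloro-4-ethoxyphenyl in place of 4-methoxyphenyl on an aromatic carbon. Within the data shown here, two measured steps bear on it. Adding a methyl to the ring gave a 3.3-fold higher number from compound 1 to compound 2 (0.51 log units; beyond the scatter), and swapping 2,4-dimethylphenyl for 4-methoxyphenyl gave a 2.3-fold lower number from compound 2 to compound 3 (0.37 log units; beyond the scatter), while a 1.4-fold higher number from compound 1 to compound 3 (0.15 log units; within the scatter) was small. A modest rise is therefore expected for compound 4, a 2.1-fold higher number from compound 3 to compound 4 (0.33 log units; beyond the scatter), giving an estimated 45 nM with a range from 18 nM to 110 nM.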

Compound 4, inhibition constant: 26 nM
Compound 4: the middle estimate sits 1.7-fold (0.24 log units) above what was measured; measured number inside the range.
By their numbers in this assay, from the lowest: compounds 1, 3, 4 and 2 (each within the scatter of the next, the first and the last beyond it).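

In this assay the 2-chloro-4-ethoxyphenyl group, on the aromatic carbon next to the ring sulfur, gives a 1.2-fold higher number from compound 3 to compound 4 (0.09 log units; within the scatter) and a 1.7-fold higher number from compound 1 to compound 4 (0.24 log units; within the scatter) and a 1.9-fold lower number from compound 2 to compound 4 (0.28 log units; within the scatter), all three within the scatter. The position thus takes a chlorine and an ethoxy together with no step beyond the scatter to any earlier compound, although compounds 1 and 2 lie beyond the scatter of each other. No measurement shown explains this result. Going by these compounds, what the chlorine and the ethoxy each do alone stays open, as they enter together in compound 4. On these data alone, how an amine or a carboxylic acid on the phenyl ring would read in this assay also stays open.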